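Methoxy Replaced by a Ring Fluorine: Expected Lipophilicity

This account rests on a few compounds, and the source may have more. Where it says the series, first, only, none or still open, it means among the compounds named here.

Compound 1 `COc1ccc(-c2nnc(COc3cnn(C(C)(C)C)c(=O)c3Cl)o2)cc1` gives 3.52 in a physicochemical assay for lipophilicity; on this read-out higher numbers stand for higher lipophilicity and lower numbers for lower lipophilicity. Within the data shown here, of the two numbers measured so far this is the lowest, and its only neighbour is compound 2 `CC(C)(C)n1ncc(OCc2nnc(-c3ccc(C(F)(F)F)cc3)o2)c(Cl)c1=O`, which gives 3.66 in this assay, a difference that is a number 0.14 log units higher from compound 1 to compound 2 (within the scatter). Compound 3 `CC(C)(C)n1ncc(OCc2nnc(-c3cccc(F)c3)o2)c(Cl)c1=O` has not yet been measured. It differs from compound 1 in one place: 3-fluorophenyl in place of 4-methoxyphenyl on an aromatic carbon.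

Among the measured compounds shown here, the one measured step that touches this position is the exchange of trifluoromethyl for methoxy between compound 1 and compound 2, and it barely moved the read-out. Replacing the methoxy group by a fluorine on the same ring is an exchange of a similar kind, so the movement in this assay is expected to be modest as well. The step expected here is a number 0.13 log units higher from compound 1 to compound 3 (within the scatter), again within the usual scatter. The estimate for compound 3 is 3.65, with a likely range from 3.35 to 3.95.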

Compound 3, partition coefficient: 2.69
The estimate for compound 3 lay 0.96 log units above the measured number; measured number outside the range, below it.
By their numbers in this assay, from the lowest: compound 3; then compounds 1 and 2 (each within the scatter of the next).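

In this assay, among these compounds, exchanging 4-methoxyphenyl for 3-fluorophenyl on the aromatic carbon of the five-membered ring gives a number 0.83 log units lower from compound 1 to compound 3 (beyond the scatter), the first step at this position that clearly exceeds the noise between repeated measurements. The earlier exchange of trifluoromethyl for methoxy gave only a number 0.14 log units higher from compound 1 to compound 2 (within the scatter), so a small step for one replacement on this ring did not carry over to another, and the read-out here clearly depends on what this position carries. No measurement is available that would explain this difference between the two steps.

The step from compound 1 to compound 3 changes two things at once, the group on the benzene ring and the number that marks its place in the group's name, and the compounds shown cannot separate these two contributions. Compounds carrying 3-methoxyphenyl, 4-fluorophenyl or plain phenyl at this position would help to tell them apart, while a phenyl ring bearing an amine or a carboxylic acid would show how far the read-out moves with groups of a quite different kind.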